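The source may hold more compounds than are shown below. What is called first, only, known or untested is meant among the compounds shown, and "the series" means these compounds.

Compound 1 `O=C(/C(=C\c1ccc(Br)cc1)SCc1ccc(Cl)cc1)c1ccc(Cl)cc1`: 1000 nM
Compound 2 `O=C(/C(=C\c1cccc(Cl)c1Cl)SCc1ccc(Cl)cc1)c1ccc(Br)cc1`: 10000 nM
Compound 3 `O=C(/C(=C\c1ccc(O)cc1)SCc1ccc(Cl)cc1)c1ccc(Cl)cc1`: 10000 nM

In a functional assay on DU-145 cells (Homo sapiens) for inhibition, read by trypan blue exclusion, with a stated time of 96 h (on this read-out higher numbers stand for weaker inhibition of growth and lower numbers for stronger inhibition of growth), compound 3 stands level with compound 2, together the highest of the three numbers, and compound 1 lies lower. Compound 4 `O=C(/C(=C\c1cccc(Cl)c1Cl)SCc1ccc(Cl)cc1)c1ccc(Cl)cc1` carries 2,3-dichlorophenyl in place of 4-hydroxyphenyl on a double-bonded chain carbon bound to a double-bonded chain carbon. Among the measured compounds shown here, one measured step bears on this change: a 10-fold higher number from compound 1 to compound 3 (1.00 log units; beyond the scatter), a modest hydroxy-for-bromo exchange. Leaving the hydroxy group could therefore lower the number. Against that, compound 2, which also carries 2,3-dichlorophenyl, gives 10000 nM. No step beyond the scatter is therefore expected in this assay, with only a slight lean downward. The expected step is a 1.3-fold lower number from compound 3 to compound 4 (0.10 log units; within the scatter). The estimate for compound 4 is 8000 nM, with an expected range of 2500 nM to 20000 nM.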

Compound 4, concentration for 50% growth inhibition: 10000 nM
Beside the measured number, compound 4's estimate is 1.3-fold (0.10 log units) below it; the range from low to high includes it.
By their numbers in this assay, from the lowest: compound 1; then compounds 2, 3 and 4 (each within the scatter of the next).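

In this assay, 2,3-dichlorophenyl and 4-hydroxyphenyl on a double-bonded chain carbon bound to a double-bonded chain carbon read alike, with no change at the digits printed from compound 3 to compound 4 (within the scatter), so removing the hydroxy group does not by itself restore the level of the 4-bromophenyl compound, given a 10-fold higher number from compound 1 to compound 4 (1.00 log units; beyond the scatter). Exchanging a bromo group for a chloro group also leaves the reading level, with no change at the digits printed from compound 2 to compound 4 (within the scatter). No measurement at hand accounts for these results. From the compounds shown here alone, what an amine or a carboxylic acid on this carbon would give remains open. So does whether the lower number of compound 1 belongs to the bromo group itself or to the placing of a single halogen.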